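The source may hold more compounds than are shown below. What is called first, only, known or untested is meant among the compounds shown, and "the series" means these compounds.

Measured compounds:
compound 1 `CCCCCCCCCCCCCCCCCCNC(=O)[C@H]1CSC(C2CCCCC2)N1` gives 9300 nM in a functional assay on PPC-1 cells (Homo sapiens) for antiproliferative activity, read by sulforhodamine B assay; a lower number here means a stronger inhibitor, a higher number a weaker inhibitor
compound 2 `CCCCCCCCCCCCCCCCCCNC(=O)[C@H]1CSC(c2ccc(N(C)C)cc2)N1` gives 1100 nM
compound 3 `CCCCCCCCCCCCCCCCCCNC(=O)[C@H]1CSC(c2cccc(O)c2)N1` gives 1200 nM

Compound 1 has the highest number of the three. Both measured steps from it replace cyclohexyl on a saturated ring carbon with a substituted phenyl: an 8.5-fold lower number from compound 1 to compound 2 (0.93 log units; beyond the scatter) and a 7.8-fold lower number from compound 1 to compound 3 (0.89 log units; beyond the scatter). Compounds 2 and 3 differ by a 1.1-fold higher number from compound 2 to compound 3 (0.04 log units; within the scatter), so the two substituted phenyls give numbers that cannot be told apart.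

Compound 4 `CCCCCCCCCCCCCCCCCCNC(=O)[C@H]1CSC(c2ccc(F)c(Br)c2)N1` makes the same kind of change: 3-bromo-4-fluorophenyl in place of cyclohexyl on a saturated ring carbon. Both prior steps bear on it and point the same way, so a step of comparable size, to a lower number, is expected: a 7.2-fold lower number from compound 1 to compound 4 (0.85 log units; beyond the scatter). Compound 4 is estimated at 1300 nM, with a range of 500 nM to 3500 nM.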

Compound 4, half-maximal inhibitory concentration: 4700 nM
Beside the measured number, compound 4's estimate is 3.6-fold (0.56 log units) below it; measured number outside the range, above it.
By their numbers in this assay, from the lowest: compounds 2 and 3 (each within the scatter of the next); then compounds 4 and 1 (each within the scatter of the next).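

In this assay, a substituted phenyl in place of cyclohexyl does not by itself separate a compound from compound 1: 3-bromo-4-fluorophenyl gives a step within the scatter (a 2.0-fold lower number from compound 1 to compound 4 (0.30 log units; within the scatter)). The substitution on the phenyl therefore matters at this saturated ring carbon, as 3-bromo-4-fluorophenyl reads apart from 3-hydroxyphenyl (a 3.9-fold higher number from compound 3 to compound 4 (0.59 log units; beyond the scatter)) and from 4-(dimethylamino)phenyl (a 4.3-fold higher number from compound 2 to compound 4 (0.63 log units; beyond the scatter)). No evidence is available to account for this spread.

Open, on these data alone, is whether the bromine or the fluorine carries the difference, which 3-bromophenyl and 4-fluorophenyl would separate. Also open, as far as these compounds go, is how a carboxylic acid on the phenyl would read here.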